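Myosin-2 series: alkyl swap on the double-bonded nitrogen

The source may report more compounds than this note shows. Statements on the series, on what has been measured and on what is new or still open speak of the compounds shown alone.

Compound 1 `C/C(=N\C(C)C)c1c(O)c2ccccc2[nH]c1=O` gives >= 100000 nM in an assay on isolated protein for inhibition of myosin-2 (Bos taurus), read by spectrophotometry, with a stated time of 24 min; a lower number here means a stronger inhibitor, a higher number a weaker inhibitor.
Compound 2 `C/C(=N\CCO)c1c(O)c2ccccc2oc1=O` gives 92000 nM in this assay.
Compound 3 `C/C(=N\C(C)C)c1c(O)c2ccccc2oc1=O` gives >= 100000 nM in this assay.

The value of compound 1 is a limit of the assay, not a number. The value of compound 3 is likewise only a limit. Going by the values given here, compound 2 alone gives a measured number, and the one measured step, an at least 1.0-fold higher number from compound 2 to compound 3 (0.03 log units; that floor lies within the scatter), sits within the scatter, so the two cores with these side chains show no resolved difference. Compound 4 `CCCCC/N=C(\C)c1c(O)c2ccccc2[nH]c1=O` differs from compound 1 by pentyl in place of isopropyl on a double-bonded nitrogen. Among the compounds with values here, no measured step exchanges one alkyl for another on the double-bonded nitrogen; the nearest comparison is an at least 1.0-fold higher number from compound 2 to compound 3 (0.03 log units; that floor lies within the scatter), which points to no movement beyond the scatter. Because (the limit of >= 100000 nM in this assay, at which 2 of the 3 values shown sit), compound 1 offers no room for a resolved rise. Compound 4 is therefore expected at 100000 nM, with a range from 40000 nM to 300000 nM, meaning an expected a number no higher from compound 1 to compound 4 (the limit leaves the size open), most likely reported again as a limit.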

Compound 4, half-maximal inhibitory concentration: >= 100000 nM
Compound 4: a limit, no number; the forecaster's own chance of this, stated with the estimate: 70%; the middle value lies on the limit itself.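

Compound 1 and compound 4 both give only limits in this assay, not numbers, so the swap of isopropyl for pentyl cannot be read. Still open, as far as these compounds go, is whether any alkyl group on the double-bonded nitrogen gives the core of compound 1 a measurable number.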